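The compounds below may be only part of what the source reports. "The series", "measured", "known", "first", "only" and "open" are said of these compounds alone.

Measured compounds:
compound 1 `CCN(Cc1ccccc1)c1cccc(C(=O)N2CCc3ccc(OS(N)(=O)=O)cc3C2)c1` with 17.3% in an assay on HEK293 cells for inhibition of Steryl-sulfatase (Homo sapiens), tested at 0.1 uM; on this read-out higher numbers stand for a stronger effect at the one concentration tested and lower numbers for a weaker effect
compound 2 `NS(=O)(=O)Oc1ccc2c(c1)CN(C(=O)c1cccc(N(CCCO)Cc3ccccc3)c1)CC2` with 25.8% in this assay

Compound 1 stands lowest of the two numbers, but its nearest neighbour is compound 2, and that step, a number 8.5 percentage points higher from compound 1 to compound 2 (within the scatter), is within the scatter, so the two are not told apart.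

The unmeasured compound 3 `CCN(Cc1ccccn1)c1cccc(C(=O)N2CCc3ccc(OS(N)(=O)=O)cc3C2)c1` differs from compound 1 by pyridin-2-yl in place of phenyl on a saturated chain carbon bound to a nitrogen on an aromatic ring. Among the compounds with values here, no measured step touches this place: the only step known, from compound 1 to compound 2, alters a saturated chain carbon two bonds along the chain from the ring nitrogen and not the benzyl ring itself, and it was small. There is therefore no ground to expect a step beyond the scatter in this assay for compound 3 in either direction.

Compound 3 is estimated at 18% in this assay, the range running from 4% to 34%, an expected step of a number 0.7 percentage points higher from compound 1 to compound 3 (within the scatter).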

Compound 3, a percentage reported as inhibition, at one concentration (the size of the read-out at that concentration, not a potency): 6.5%
Estimate against measurement, compound 3: 11.5 percentage points above, and the stated range covers the measured number.
By their numbers in this assay, from the lowest: compound 3; then compounds 1 and 2 (each within the scatter of the next).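

In this assay, within the data shown here, putting pyridin-2-yl in place of phenyl on the saturated chain carbon bound to a nitrogen on an aromatic ring gives a number 10.8 percentage points lower from compound 1 to compound 3 (beyond the scatter), a modest change but the only step here that lies beyond the scatter. The ring itself is therefore a place where exchanging one carbon for one nitrogen, which adds a hydrogen-bond acceptor to the count, moves the read-out, whereas the hydroxymethyl change on the chain gave a number 8.5 percentage points higher from compound 1 to compound 2 (within the scatter). Nothing available bears on why this exchange lowers the number.

On these data alone, it remains open whether other replacements for phenyl, such as a thiophene or pyrimidine ring, would lower the number in the same way. As far as these compounds go, it is also open whether a methoxy group or a fluorine on the phenyl ring would change it at all.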